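Extending the aromatic end group of a calpain-1 inhibitor

This account rests on a few compounds, and the source may have more. Where it says the series, first, only, none or still open, it means among the compounds named here.

Measured compounds:
- compound 1 `CCC(NC(=O)C(CC(C)C)NC(=O)OCc1ccccc1)C(=O)C(=O)NCC1CCCCC1`: 680 nM
- compound 2 `CCC(NC(=O)C(CC(C)C)NC(=O)OCc1ccccc1)C(=O)C(=O)NCC1(C)CC(O)CC(C)(C)C1`: 420 nM
- compound 3 `CCC(NC(=O)C(CC(C)C)NC(=O)OCc1ccccc1)C(=O)C(=O)NCc1ccccc1`: 200 nM

All three share one core and differ only in the group attached on a saturated chain carbon bound to an amide-type nitrogen. In an assay on isolated protein for inhibition of Calpain-1 catalytic subunit (Homo sapiens) (a higher number here means a weaker inhibitor, a lower number a stronger inhibitor), compound 3 gives the lowest number of the three, with the steps of a 3.4-fold lower number from compound 1 to compound 3 (0.53 log units; beyond the scatter) and a 2.1-fold lower number from compound 2 to compound 3 (0.32 log units; beyond the scatter) both reaching beyond the scatter, while the step of a 1.6-fold lower number from compound 1 to compound 2 (0.21 log units; within the scatter) stays within it. Compound 3 is therefore the strongest inhibitor among the measured set.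

Compound 4 `CCC(NC(=O)C(CC(C)C)NC(=O)OCc1ccccc1)C(=O)C(=O)NCc1nccc2ccccc12` carries the change (isoquinolin-1-yl in place of phenyl on a saturated chain carbon bound to an amide-type nitrogen). For the measured compounds named here, the steps measured so far all swap one six-membered ring for another on this carbon; none of them adds a second fused aromatic ring or a hydrogen-bond acceptor, so there is no direct precedent. What they do show is that the aromatic ring in compound 3 sits better than either saturated ring, and that changes at this position move the number only modestly. On that basis a step of similar modest size is expected, most likely a small further lowering, though a result within the scatter would not surprise. Compound 4 is expected to give about 140 nM in this assay, in a range from 55 nM to 400 nM, meaning a step of a 1.4-fold lower number from compound 3 to compound 4 (0.15 log units; within the scatter).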

Compound 4, inhibition constant: 250 nM
Compound 4: the middle estimate sits 1.8-fold (0.25 log units) below what was measured, and the stated range covers the measured number.
By their numbers in this assay, from the lowest: compounds 3, 4, 2 and 1 (each within the scatter of the next, the first and the last beyond it).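

In this assay, replacing phenyl with the larger isoquinolin-1-yl, which brings an extra aromatic ring and a hydrogen-bond acceptor, gives a 1.3-fold higher number from compound 3 to compound 4 (0.10 log units; within the scatter), so at this position the larger group leaves the number indistinguishable from that of the phenyl compound. Compared with the saturated groups, the result is mixed: isoquinolin-1-yl gives a 2.7-fold lower number from compound 1 to compound 4 (0.43 log units; beyond the scatter) against cyclohexyl, yet a 1.7-fold lower number from compound 2 to compound 4 (0.23 log units; within the scatter) against the substituted saturated ring, so compound 2 goes against any simple rule that an aromatic group here always beats a saturated one. No supporting data are available to explain these numbers, so the contributions of the ring nitrogen and of the extra ring remain unassigned.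

The compounds shown leave open which part of isoquinolin-1-yl matters, since that group differs from phenyl in both the extra ring and the ring nitrogen. Naphthalen-1-yl would carry the extra ring without the nitrogen and pyridin-2-yl the nitrogen without the extra ring, and neither is among these compounds, so the two changes cannot yet be told apart.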